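Bromine on the aryl arm: a step in the gastric cancer assay

A few compounds are considered here, and "the series" means these few. Any claim that something is new, unique, unknown or untested is made for them only; others in the source may bear on it.

Measured compounds in a functional assay on MGC-803 cells (Homo sapiens) for inhibition, read by MTT assay, with a stated time of 72 h; a lower number here means a stronger inhibitor, a higher number a weaker inhibitor:
Compound 1 `Cc1ccc(Nc2nc(SCc3cn(Cc4ccccc4Cl)nn3)nc(-c3ccccc3)c2C#N)cc1` gives 7190 nM.
Compound 2 `Cc1ccc(Nc2nc(SCc3cn(Cc4ccccc4Cl)nn3)nc(-c3ccc(C)cc3)c2C#N)cc1` gives 24400 nM.
Compound 3 `COc1cc(-c2nc(SCc3cn(Cc4ccccc4Cl)nn3)nc(Nc3ccc(C)cc3)c2C#N)cc(OC)c1OC` gives 30800 nM.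

Compound 3 carries the highest number of the three; its number stands near that of compound 2 within the scatter, and beyond it only against compound 1, as a 4.3-fold higher number from compound 1 to compound 3 (0.63 log units; beyond the scatter) shows. Compound 4 `Cc1ccc(Nc2nc(SCc3cn(Cc4ccccc4Cl)nn3)nc(-c3ccc(Br)cc3)c2C#N)cc1` arises from compound 3 by a single change: 4-bromophenyl in place of 3,4,5-trimethoxyphenyl on an aromatic carbon. Among the compounds with values here, two measured steps bear on this. The step of a 3.4-fold higher number from compound 1 to compound 2 (0.53 log units; beyond the scatter) shows that a substituent on this aryl ring raises the number, while a 1.3-fold higher number from compound 2 to compound 3 (0.10 log units; within the scatter) shows two differently substituted aryl rings sitting within the scatter of each other. Compound 4, with a single bromine on its aryl ring, is therefore expected to land near compound 2, with a step of a 1.9-fold lower number from compound 3 to compound 4 (0.28 log units; within the scatter) that may or may not pass the scatter. The estimate for compound 4 in this assay is 16000 nM, with a range from 5000 nM to 45000 nM.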

Compound 4, half-maximal inhibitory concentration: 15600 nM
Beside the measured number, compound 4's estimate is 1.0-fold (0.01 log units) above it; measured number inside the range.
By their numbers in this assay, from the lowest: compound 1; then compounds 4, 2 and 3 (each within the scatter of the next).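

In this assay, a third kind of substituted aryl ring falls in with the other two: bromo for methyl gives a 1.6-fold lower number from compound 2 to compound 4 (0.19 log units; within the scatter), and 4-bromophenyl for 3,4,5-trimethoxyphenyl gives a 2.0-fold lower number from compound 3 to compound 4 (0.30 log units; within the scatter). Bromo for hydrogen still gives a 2.2-fold higher number from compound 1 to compound 4 (0.34 log units; beyond the scatter), so at this position the substituted rings differ from the unsubstituted phenyl ring, while the choice among these three substituents cannot be told apart. Nothing measured here explains this. From the compounds shown here alone, it stays open whether an amine or a carboxylic acid on this ring would follow the same pattern, and whether bromine placed elsewhere on the ring would.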